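A Methoxyphenyl Swap on an Inactive Compound

The source may hold more compounds than are shown below. What is called first, only, known or untested is meant among the compounds shown, and "the series" means these compounds.

Compound 1 `COc1ccc(/C=N/NC(=O)Nc2cc3c(Nc4ccc(F)c(Cl)c4)ncnc3cc2O[C@H]2CCOC2)cc1` gives 27300 nM
Compound 2 `COc1cc2ncnc(Nc3ccc(F)c(Cl)c3)c2cc1NC(=O)N/N=C/c1ccc(F)cc1` gives 35100 nM
Compound 3 `COc1cc2ncnc(Nc3ccc(F)c(Cl)c3)c2cc1NC(=O)N/N=C/c1ccc(F)cc1Cl` gives "not active" (no number reported)

All three were tested in a functional assay on MCF7 cells (Homo sapiens) for cytotoxicity, read by MTT assay, with a stated time of 72 h; a higher number here means a weaker inhibitor, a lower number a stronger inhibitor. Compound 3 has no single number there, whereas compound 1 and compound 2 each have one. Compound 4 `COc1ccc(/C=N/NC(=O)Nc2cc3c(Nc4ccc(F)c(Cl)c4)ncnc3cc2OC)cc1` remains unmeasured. The change 4-methoxyphenyl in place of 2-chloro-4-fluorophenyl on a carbon with a double bond to nitrogen brings 4-methoxyphenyl in place of 2-chloro-4-fluorophenyl on a carbon with a double bond to nitrogen. Compound 1 also carries 4-methoxyphenyl, on a different core, and gives 27300 nM. On that basis, a step toward stronger inhibition is expected in this assay, from no reported activity to a weak but measurable value, although its size cannot be stated. Compound 4 is estimated at 30000 nM, with an expected range of 12000 nM to 70000 nM.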

Compound 4, half-maximal inhibitory concentration: 8140 nM
Beside the measured number, compound 4's estimate is 3.7-fold (0.57 log units) above it; measured number outside the range, below it.
By their numbers in this assay, from the lowest: compound 4; then compounds 1 and 2 (each within the scatter of the next).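

In this assay, compound 4 has a measured value where compound 3 has no number, so the step between them cannot be read as a size. Methoxy in place of fluoro on an aromatic carbon gives a 4.3-fold lower number from compound 2 to compound 4 (0.63 log units; beyond the scatter), and methyl in place of oxolan-3-yl on an oxygen on an aromatic ring gives a 3.4-fold lower number from compound 1 to compound 4 (0.53 log units; beyond the scatter), both modest but beyond the scatter. As far as these compounds go, whether an amine or a carboxylic acid in place of that methoxy would give a lower number remains open, as does the effect of a longer chain on the oxygen. No evidence at hand explains these steps.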